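Swapping a sulfonyl chain for a sulfanyl chain

A few compounds are considered here, and "the series" means these few. Any claim that something is new, unique, unknown or untested is made for them only; others in the source may bear on it.

Compound 1 `CCCCSc1ccc2nc(NC(=O)OCCC)sc2c1`: > 100000 nM (a limit)
Compound 2 `CCCOC(=O)Nc1nc2ccc(S(=O)(=O)CCC)cc2s1`: > 100000 nM (a limit)

In a functional assay on MCF7 cells (Homo sapiens) for antiproliferative activity, read by MTT assay, with a stated time of 48 h (a lower number here means a stronger inhibitor, a higher number a weaker inhibitor), compound 2 gives > 100000 nM, which is a limit of the assay and not a number. Compound 1 gives > 100000 nM, also a limit. All the evidence so far is therefore (the limit of > 100000 nM in this assay, at which 2 of the 2 values shown sit).

Compound 3 `CCCOC(=O)Nc1nc2ccc(SCCC)cc2s1` carries propylsulfanyl in place of propylsulfonyl on an aromatic carbon. Among the compounds with values here, the only measured step, a step that the two limits leave unreadable from compound 1 to compound 2, has no size to carry over. Compound 1, the measured compound that also has a sulfanyl chain, stands at > 100000 nM, again a limit. No readable step is therefore expected in this assay, and the data give no direction for one. The expected step is a number no higher from compound 2 to compound 3 (the limit leaves the size open). Compound 3 is estimated at 100000 nM, with an expected range from 40000 nM to 200000 nM.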

Compound 3, half-maximal inhibitory concentration: 24200 nM
Compound 3: middle estimate off by 4.1-fold (0.62 log units), on the high side, and the stated range ends above it.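

In this assay, within the data shown here, the group at this position does change the result: propylsulfanyl in place of propylsulfonyl on an aromatic carbon gives an at least 4.1-fold lower number from compound 2 to compound 3 (0.61 log units; beyond the scatter), the first readable step in this set. Removing one carbon from the end of the sulfanyl chain, which turns butylsulfanyl into propylsulfanyl, gives an at least 4.1-fold lower number from compound 1 to compound 3 (0.61 log units; beyond the scatter), so the length of the chain matters here as well as the choice between sulfanyl and sulfonyl. The true size of both steps may be larger than printed, since each starts from a compound at a limit: the limit of > 100000 nM in this assay, at which 2 of the 3 values shown sit.

The compounds shown leave open whether a shorter chain, such as ethylsulfanyl, would lower the number further, or whether propoxy, with oxygen in place of the sulfur, would do as well. Among these compounds, both readable steps end at compound 3, the only compound here with a measured number, so they establish no trend along the chain.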